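The compounds below may be only part of what the source reports. "The series", "measured", "known", "first", "only" and "open" are said of these compounds alone.

Measured in an ADME assay on microsomes from liver (Rattus norvegicus) for metabolic stability, using NADPH, with a stated time of 10 min; on this read-out higher numbers stand for a more stable compound and lower numbers for a less stable compound:

- compound 1, `CCCCc1nc(=O)c(S(=O)(=O)c2ccc(-c3ccnc(NC(=O)C4CC4)c3)cc2)c(O)n1-c1c(OC)cccc1OC`, gives 72%
- compound 2, `CCCCc1nc(=O)c(S(=O)(=O)c2ccc(-c3ccc(F)cc3)cc2)c(O)n1-c1c(OC)cccc1OC`, gives 5%
- compound 3, `CCCCc1nc(=O)c(S(=O)(=O)c2ccccc2)c(O)n1-c1c(OC)cccc1OC`, gives 93%

Compound 3 stands highest of the three: the step of a number 21 percentage points higher from compound 1 to compound 3 (beyond the scatter) is modest, and the step of a number 88 percentage points higher from compound 2 to compound 3 (beyond the scatter) is large, both beyond the scatter. Between the two substituted compounds the step of a number 67 percentage points lower from compound 1 to compound 2 (beyond the scatter) is also large.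

Compound 4, `CCCCc1nc(=O)c(S(=O)(=O)c2ccc(C)cc2)c(O)n1-c1c(OC)cccc1OC`, differs from compound 3 only in this way: methyl in place of hydrogen on an aromatic carbon, so that the phenylsulfonyl becomes a (4-methylphenyl)sulfonyl. Both measured steps that touch this position of compound 3 concern far bigger groups than a methyl, and they point in opposite directions when read as additions: adding the 4-fluorophenyl costs a great deal, adding the pyridinyl group costs less. Going by the values given here, no measured step adds a single carbon at this position, so the guide is loose. A small loss of stability is expected for compound 4, and the expected step is a number 13 percentage points lower from compound 3 to compound 4 (beyond the scatter). The estimate for compound 4 in this assay is 80%, with a range from 55% to 95%.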

Compound 4, percent of the compound remaining: 74%
Compound 4: middle estimate off by 6 percentage points, on the high side; low and high end bracket the measured number.
By their numbers in this assay, from the lowest: compound 2; then compounds 1 and 4 (each within the scatter of the next); then compound 3.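

In this assay, the smallest change so far already counts: with one carbon added on the ring, there is a number 19 percentage points lower from compound 3 to compound 4 (beyond the scatter) and so this position responds even to a methyl. The size of the group does not order the results: there is a number 69 percentage points higher from compound 2 to compound 4 (beyond the scatter) but also a number 2 percentage points higher from compound 1 to compound 4 (within the scatter) and so the methyl and the far larger 2-((cyclopropylcarbonyl)amino)pyridin-4-yl group give matching numbers, against any rule that bigger groups lower stability, while the 4-fluorophenyl stands apart. Nothing available explains why these groups behave so differently.

The compounds shown leave open how a lone fluorine, a methoxy group, an amine or a carboxylic acid at this position would compare with the methyl. They also leave open whether an ethyl group or a longer chain would lower the number further.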